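The source may hold more compounds than are shown below. What is called first, only, known or untested is meant among the compounds shown, and "the series" means these compounds.

Measured compounds:
compound 1 `CCCC(=O)Nc1ccc(S(=O)(=O)Oc2ccccc2I)cc1`, 9000 nM
compound 2 `CC(C)(C)C(=O)Nc1ccc(S(=O)(=O)Oc2ccccc2I)cc1`, 8300 nM
compound 3 `O=C(CCCl)Nc1ccc(S(=O)(=O)Oc2ccccc2I)cc1`, 12000 nM

All three values come from a functional assay on M21 cells (Homo sapiens) for antiproliferative activity, read by sulforhodamine B assay, with a stated time of 48 h; a lower number here means a stronger inhibitor, a higher number a weaker inhibitor. Compound 3 has the highest number of the three, but its step from compound 1 a 1.3-fold higher number from compound 1 to compound 3 (0.12 log units; within the scatter) and its step from compound 2 a 1.4-fold higher number from compound 2 to compound 3 (0.16 log units; within the scatter) both lie within the scatter, as does a 1.1-fold lower number from compound 1 to compound 2 (0.04 log units; within the scatter). Compound 4 `CCCCCNC(=O)Nc1ccc(S(=O)(=O)Oc2ccccc2I)cc1` differs from compound 3 by pentylamino in place of 2-chloroethyl on a carbonyl carbon. No measured step bears directly on a pentylamino group on this carbonyl carbon; the three shown steps on that carbon were all flat, so the expected step of a 1.3-fold lower number from compound 3 to compound 4 (0.10 log units; within the scatter) is none beyond the scatter. Compound 4 is therefore estimated at 9500 nM in this assay, with a range from 4000 nM to 25000 nM.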

Compound 4, half-maximal inhibitory concentration: 5900 nM
For compound 4 the middle estimate is 1.6-fold (0.21 log units) above the measured one; the range from low to high includes it.
By their numbers in this assay, from the lowest: compounds 4, 2, 1 and 3 (each within the scatter of the next, the first and the last beyond it).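

In this assay, the carbonyl carbon gives its first step beyond the scatter, modest in size: a 2.0-fold lower number from compound 3 to compound 4 (0.31 log units; beyond the scatter), with pentylamino in place of 2-chloroethyl. Against the other two groups, pentylamino stays within the scatter: a 1.4-fold lower number from compound 2 to compound 4 (0.15 log units; within the scatter) for tert-butyl and a 1.5-fold lower number from compound 1 to compound 4 (0.18 log units; within the scatter) for propyl. So the change separates compound 4 only from compound 3, and no evidence on the origin of that step is available. Still open, as far as these compounds go, is whether a longer chain or a carboxylic acid in place of pentylamino on this carbonyl carbon would move the number beyond the scatter from compound 1 or compound 2.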